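The compounds below may be only part of what the source reports. "The series", "measured", "known", "first", "only" and "open" are said of these compounds alone.

Measured compounds in the series:

compound 1 `CC1=CC[C@H](C(C)(C)NC(=S)N/N=C/c2ccc(N(C)C)cc2)CC1`: > 100000 nM
compound 2 `CC1=CC[C@H](C(C)(C)NC(=S)N/N=C/c2ccc(F)cc2)CC1`: > 100000 nM
compound 3 `COc1cc(/C=N/NC(=S)NC(C)(C)[C@H]2CC=C(C)CC2)ccc1O`: 32600 nM

In a functional assay on U-251 cells (Homo sapiens) for inhibition, read by sulforhodamine B assay, with a stated time of 48 h (on this read-out higher numbers stand for weaker inhibition of growth and lower numbers for stronger inhibition of growth), compound 1 gives > 100000 nM, which is a limit of the assay and not a number. Compound 2 gives > 100000 nM, likewise a limit. Within the data shown here, compound 3 gives 32600 nM, the one value in this assay that is a number. Among the measured compounds shown here, the single step between measured compounds, a step that the two limits leave unreadable from compound 1 to compound 2, has no readable size because of the limit of > 100000 nM in this assay, at which 2 of the 3 values shown sit. Compound 2 therefore stands at the limit, with no number placing it against compound 3 beyond the fact that compound 3 does return a value.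

Compound 4 `CC1=CC[C@H](C(C)(C)NC(=S)N/N=C/c2ccco2)CC1` differs from compound 2 by furan-2-yl in place of 4-fluorophenyl on a carbon with a double bond to nitrogen. For the measured compounds named here, no measured step bears on this change: the only step in hand is unreadable, and no pair varies the aryl ring for a five-membered heteroaryl. The expectation for compound 4 rests on compound 2 alone and its limit > 100000 nM; the step of a number no higher from compound 2 to compound 4 (the limit leaves the size open) is expected to be none beyond the scatter, most likely with the assay again returning only a limit. Compound 4 is estimated at 100000 nM, in the range 30000 nM to 300000 nM.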

Compound 4, concentration for total growth inhibition: 81500 nM
Compound 4: middle estimate off by 1.2-fold (0.09 log units), on the high side; the measured number falls inside the stated range.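

In this assay furan-2-yl on the carbon with a double bond to nitrogen returns a number, with compound 4 at 81500 nM. Compound 2, carrying 4-fluorophenyl in the same place, gives > 100000 nM, which is a limit of the assay and not a number. The change is therefore read only as an at least 1.2-fold lower number from compound 2 to compound 4 (0.08 log units; that floor lies within the scatter), and its true size stays open because of that limit: the limit of > 100000 nM in this assay, at which 2 of the 4 values shown sit.

The compounds shown leave open whether the ring oxygen of furan-2-yl matters, which a thiophen-2-yl group on the same carbon, with sulfur in place of that oxygen, would address. Among these compounds, also open is what the aryl groups carried by the other compounds contribute, since the only step among them cannot be read and compound 3, at 32600 nM, differs from the rest in more than one place.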